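The source may hold more compounds than are shown below. What is called first, only, known or untested is meant among the compounds shown, and "the series" means these compounds.

Working notes on the series. In an ADME assay on Jurkat cells (Homo sapiens) for cytotoxicity, read by WST assay, with a stated time of 48 h (on this read-out higher numbers stand for lower toxicity in this test and lower numbers for higher toxicity in this test), compound 1 `N#Cc1c(-c2ccc(Cl)cc2)nc(SCc2ccccc2)nc1N1CCC(C(N)=O)CC1` gives > 10000 nM, which is a limit of the assay and not a number. Compound 2 `COc1ccc(-c2nc(SCc3ccccc3)nc(NCc3ccccc3)c2C#N)cc1` in this assay likewise returns only a limit, > 10000 nM. Within the data shown here, compound 2 thus stands at the limit of > 10000 nM in this assay, at which 2 of the 2 values shown sit, and has no number of its own to set against compound 1; the two values show only that both compounds sit at the same limit. Compound 3 `COc1ccc(-c2nc(SCc3ccccc3)nc(N3CCC(C(N)=O)CC3)c2C#N)cc1` has not yet been measured in this assay. It differs from compound 2 by 4-carbamoylpiperidin-1-yl in place of benzylamino on an aromatic carbon. Compound 1 already carries the 4-carbamoylpiperidin-1-yl group, and because compound 1 sits at the limit given by the limit of > 10000 nM in this assay, at which 2 of the 2 values shown sit, no step beyond the scatter is expected. The expected step is a step that the limit leaves unreadable from compound 2 to compound 3. Compound 3 is estimated at 15000 nM in this assay, within 7000 nM to 40000 nM, most likely reported again only as a limit.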

Compound 3, half-maximal cytotoxic concentration: > 10000 nM
Compound 3: no number, only a limit; the forecaster's own chance of this, stated with the estimate: 85%; the middle value lies beyond the limit too.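

No step can be read among compound 1, compound 2 and compound 3 in this assay, as each returns only a limit of the assay and not a number: the limit of > 10000 nM in this assay, at which 3 of the 3 values shown sit. The compounds shown leave open how far each lies beyond that limit, and whether 4-carbamoylpiperidin-1-yl in place of benzylamino or methoxy in place of chloro changes the read-out at all.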